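Acyl chain growth on the anilide of the shared core

The compounds below may be only part of what the source reports. "The series", "measured", "known", "first", "only" and "open" are said of these compounds alone.

Three anilides of the shared core have been measured in a functional assay for inhibition, with Homo sapiens as the target; a lower number here means that less compound is needed, a higher number that more compound is needed for the effect. Compound 1 `O=CNc1ccc(C2=NNC(=O)CC2)cc1` gives 3.74 ug/mL; compound 2 `CCC(=O)Nc1ccc(C2=NNC(=O)CC2)cc1` gives 0.64 ug/mL; compound 3 `O=C1CCC(c2ccc(NC(=O)CCl)cc2)=NN1` gives 0.39 ug/mL. Compound 3 has the lowest of the three numbers, yet against compound 2 it stands only a 1.6-fold lower number from compound 2 to compound 3 (0.22 log units; within the scatter), which is within the scatter; only against compound 1 does the gap count, at a 9.6-fold lower number from compound 1 to compound 3 (0.98 log units; beyond the scatter).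

Compound 4 `CCC(Cl)C(=O)Nc1ccc(C2=NNC(=O)CC2)cc1` carries ethyl in place of hydrogen on a saturated chain carbon bound to a carbonyl carbon and a chlorine atom. Among the measured compounds shown here, the steps that bear on it are those that enlarge the acyl group on the carbonyl carbon: a 5.8-fold lower number from compound 1 to compound 2 (0.77 log units; beyond the scatter) and a 9.6-fold lower number from compound 1 to compound 3 (0.98 log units; beyond the scatter), both modest and both toward lower numbers. For the measured compounds named here, the change from compound 3 to compound 4 is smaller in kind, adding a chain to a carbon that already bears chlorine, and no step tests a chain at that place. A step of a 1.3-fold lower number from compound 3 to compound 4 (0.11 log units; within the scatter) is therefore expected, toward a lower number if any, but likely within the scatter. Compound 4 is estimated at 0.3 ug/mL, with a range of 0.1 ug/mL to 0.9 ug/mL.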

Compound 4, half-maximal effective concentration: 1.47 ug/mL
Beside the measured number, compound 4's estimate is 4.9-fold (0.69 log units) below it; the whole stated range lies below it.
By their numbers in this assay, from the lowest: compounds 3 and 2 (each within the scatter of the next); then compound 4; then compound 1.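

In this assay, among the compounds shown here, ethyl in place of hydrogen on the saturated chain carbon bound to a carbonyl carbon and a chlorine atom gives a 3.8-fold higher number from compound 3 to compound 4 (0.58 log units; beyond the scatter), a direction that no earlier step showed. Growth of the acyl group therefore does not keep lowering the number: the larger group on the carbonyl carbon gives a 2.3-fold higher number from compound 2 to compound 4 (0.36 log units; beyond the scatter), although a 2.5-fold lower number from compound 1 to compound 4 (0.41 log units; beyond the scatter) still shows a gain over hydrogen at that place, so compound 4 goes against any simple trend with acyl size. No measured evidence accounts for this reversal.

The compounds shown leave open whether the rise depends on the chlorine atom staying on that carbon. They also leave open how a methyl, a longer chain or an amine at the same carbon would compare.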